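The compounds below may be only part of what the source reports. "The series", "measured", "known", "first", "only" and "open" are said of these compounds alone.

Within the data shown here, in a functional assay on HCT-116 cells (Homo sapiens) for cytotoxicity, read by sulforhodamine B assay, with a stated time of 24 h (a lower number here means a stronger inhibitor, a higher number a weaker inhibitor), compound 1 (`N#CCC(=O)N/N=C1\C(=O)Nc2ccc(S(=O)(=O)N3CCOCC3)cc21`) gives 10300 nM and compound 2 (`Cc1ccc(/N=C2\C(=O)Nc3ccc(S(=O)(=O)N4CCOCC4)cc32)cc1`) gives 18900 nM with no other measured compound to set them against. Compound 3 (`Cc1ccc(S(=O)(=O)N/N=C2\C(=O)Nc3ccc(S(=O)(=O)N4CCOCC4)cc32)cc1`) is compound 1 with (4-methylphenyl)sulfonyl in place of (cyanomethyl)carbonyl on an amine nitrogen. Among the measured compounds shown here, the one measured step that bears on this (a 1.8-fold higher number from compound 1 to compound 2 (0.26 log units; within the scatter)) also removes (cyanomethyl)carbonyl and brings in 4-methylphenyl, and it stays within the scatter, so no step beyond the scatter is expected in this assay here. Compound 3 is therefore estimated at 12000 nM within an expected range (4500 nM to 30000 nM). That estimate means an expected step (a 1.2-fold higher number from compound 1 to compound 3 (0.07 log units; within the scatter)).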

Compound 3, half-maximal inhibitory concentration: 23400 nM
Estimate against measurement, compound 3: 2.0-fold (0.29 log units) below, and the stated range covers the measured number.
By their numbers in this assay, from the lowest: compounds 1, 2 and 3 (each within the scatter of the next, the first and the last beyond it).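

In this assay, placing (4-methylphenyl)sulfonyl on the amine nitrogen in place of (cyanomethyl)carbonyl gives a 2.3-fold higher number from compound 1 to compound 3 (0.36 log units; beyond the scatter). This shows that the position responds to the group it carries, though only modestly, and that this larger group with its aromatic ring does not bring a lower number. No available evidence accounts for the step.

On these data alone, it remains open whether the sulfonyl link or the aromatic ring drives the step, which a methylsulfonyl or benzoyl group on the same nitrogen could help to separate.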